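The source may report more compounds than this note shows. Statements on the series, on what has been measured and on what is new or still open speak of the compounds shown alone.

Working notes on the series. Compound 1 `NCCCCN(C[C@@H]1Cc2ncccc2CN1)[C@H]1CCCc2cccnc21`, compound 2 `NCCCCN(C[C@@H]1Cc2cccnc2CN1)[C@H]1CCCc2cccnc21` and compound 3 `NC(=O)NC/C=C/CN(C[C@H]1Cc2ncccc2CN1)[C@H]1CCCc2cccnc21` have been run in an ADME assay on microsomes from liver (Homo sapiens) for metabolic stability, using NADPH, with a stated time of 10 min; on this read-out higher numbers stand for a more stable compound and lower numbers for a less stable compound. In this assay compound 1 gives 98%, compound 2 gives 92%, and compound 3 gives 93%. Compound 3 stands second highest of the three numbers; its nearest neighbour is compound 2, within the scatter, and the furthest is compound 1, also within the scatter, so all three sit at one level. Compound 4 `c1cnc2c(c1)CN[C@@H](CN(CCCC1CCNCC1)[C@H]1CCCc3cccnc31)C2` is not yet measured in this assay. Against compound 3 it differs in one place: a group of 8 heavy atoms (7 carbon, 1 nitrogen; one six-membered non-aromatic ring with 1 hetero atom) in place of a group of 7 heavy atoms (4 carbon, 2 nitrogen, 1 oxygen; no ring), on a saturated chain carbon bound to an amine nitrogen. Within the data shown here, no step between measured compounds is available. Since every measured compound sits high in this assay, no step beyond the scatter is expected in either direction. Compound 4 is estimated at 90%, with a range from 75% to 99%. This corresponds to an expected step of a number 3 percentage points lower from compound 3 to compound 4 (within the scatter).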

Compound 4, percent of the compound remaining: 100%
The estimate for compound 4 lay 10 percentage points below the measured number; the whole stated range lies below it.
By their numbers in this assay, from the lowest: compounds 2, 3, 1 and 4 (each within the scatter of the next).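

In this assay the change to 2-(piperidin-4-yl)ethyl gives a number 7 percentage points higher from compound 3 to compound 4 (within the scatter) on a saturated chain carbon bound to an amine nitrogen, so this place accepts a six-membered non-aromatic ring as well as a group with no ring, with the read-out staying at one level. The same holds with both double bonds outside aromatic rings gone and one hydrogen-bond donor fewer. No measurement here bears on the reason for this result. On these data alone, whether a carboxylic acid or a longer chain at this place stays at this level remains open. So does whether a piperidine ring without the ethyl link does.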